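Cytotoxicity limit held across the ester series?

This account rests on a few compounds, and the source may have more. Where it says the series, first, only, none or still open, it means among the compounds named here.

In an ADME assay on Vero cells (Chlorocebus sabaeus) for cytotoxicity, read by MTT assay, with a stated time of 48 h (a higher number here means a weaker inhibitor, a lower number a stronger inhibitor), compound 1 (`O=C(OC1CCC(CN2CCN(c3cc(=O)c4cc(C(F)(F)F)cc([N+](=O)[O-])c4s3)CC2)CC1)c1cccc(C(F)(F)F)c1`) gives > 64 ug/mL, which is a limit of the assay. Compound 2 (`O=C(OC1CCC(CN2CCN(c3cc(=O)c4cc(C(F)(F)F)cc([N+](=O)[O-])c4s3)CC2)CC1)c1cccc(F)c1`) gives > 64 ug/mL, also a limit, so it has no numerical position in the series. The two compounds share one reading: the limit of > 64 ug/mL in this assay, at which 2 of the 2 values shown sit.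

Compound 3 (`CC(=O)OC1CCC(CN2CCN(c3cc(=O)c4cc(C(F)(F)F)cc([N+](=O)[O-])c4s3)CC2)CC1`) carries methyl in place of 3-fluorophenyl on a carbonyl carbon, the acetoxy group replacing ((3-fluorophenyl)carbonyl)oxy: methyl in place of 3-fluorophenyl on a carbonyl carbon.

Among the compounds with values here, the only measured step that bears on this is a step that the two limits leave unreadable from compound 1 to compound 2, and it gives no size to carry forward. Within the data shown here, it also exchanged fluoro for trifluoromethyl on an aromatic carbon, whereas no measured step removes the 3-fluorophenyl itself. The evidence therefore supplies no direction for the change in this assay, and no shift beyond the scatter is anticipated. Compound 3 will most likely be reported as a limit as well.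

The expected change is a step that the limit leaves unreadable from compound 2 to compound 3, an estimate that carries no firm direction. For compound 3 the estimated value is 70 ug/mL, with an expected range of 32 ug/mL to 128 ug/mL.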

Compound 3, half-maximal inhibitory concentration: > 64 ug/mL
Compound 3: no number, only a limit; the forecaster's own chance of this, stated with the estimate: 85%; the middle value does not contradict the limit.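

No step can be read among compound 1, compound 2 and compound 3 in this assay, because all three share one reading, which is a limit and not a number: the limit of > 64 ug/mL in this assay, at which 3 of the 3 values shown sit.

The compounds shown leave open how far past that limit each one lies, and so whether the groups on the carbonyl carbon differ at all in cytotoxicity.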